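Removing the nitrile from compound 1 in the anilide series

The source may report more compounds than this note shows. Statements on the series, on what has been measured and on what is new or still open speak of the compounds shown alone.

Three compounds carry a number in a functional assay on HEK293 cells for agonist activity at D(4) dopamine receptor (Homo sapiens), read by FLIPR; on this read-out higher numbers stand for an effect only at larger amounts of compound and lower numbers for an effect already at smaller amounts. Compound 1 `Cc1cccc(NC(=O)CN2CCC(c3ccccc3C#N)CC2)c1` gives 8 nM, the lowest of the three. Compound 2 `Cc1ccc(C(=O)NCN2CCC(c3cccc[n+]3[O-])CC2)cc1C` gives 38 nM, a number beyond the scatter above compound 1, and compound 3 `COc1cccc(C(=O)NCN2CCC(c3cccc[n+]3[O-])CC2)c1C` gives 685 nM, further above still. Compounds 2 and 3 differ from compound 1 in several places at once, so their gaps to compound 1 do not isolate any single change.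

Compound 4 `Cc1cccc(NC(=O)CN2CCC(c3ccccc3)CC2)c1` is not yet measured. It differs from compound 1 in one place: hydrogen in place of cyano on an aromatic carbon The place is ortho to a large group, and the cyano is the only hydrogen-bond acceptor lost. Among the compounds with values here, no step between measured compounds shows this change, so there is no direct precedent in this set.

The expectation is a rise in the number, of moderate size and beyond the scatter. The step from compound 1 to compound 4 is estimated as a 4.4-fold higher number from compound 1 to compound 4 (0.64 log units; beyond the scatter). Compound 4 is expected to give about 35 nM in this assay, with a range from 8 nM to 150 nM.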

Compound 4, half-maximal effective concentration: 170 nM
The estimate for compound 4 lay 4.9-fold (0.69 log units) below the measured number, outside the stated range (above it).
By their numbers in this assay, from the lowest: compound 1; then compound 2; then compound 4; then compound 3.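

In this assay, going from 2-cyanophenyl to phenyl gives a 21-fold higher number from compound 1 to compound 4 (1.33 log units; beyond the scatter), a large step and the first in the set that isolates a single change. This position, ortho to a large group, is therefore not indifferent to its substituent: with the rest of the structure held fixed, cyano gives the lower number and hydrogen the higher. Nothing available bears on why the step is this large.

As far as these compounds go, only cyano and hydrogen are compared at this position, so it remains open whether fluorine, chlorine, methoxy or a carboxamide would keep the number close to that of compound 1 at 8 nM. Also open, from the compounds shown here alone, is whether the same replacement gives a step of this size when the methyl group on the anilide is absent.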